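The source may hold more compounds than are shown below. What is called first, only, known or untested is meant among the compounds shown, and "the series" means these compounds.

For the measured compounds named here, compound 2 `CS(=O)(=O)Nc1ccc(NC(=O)Nc2cccc(-c3nc(-c4ccc(NC(=O)c5cccnc5)cc4Cl)no3)c2)cc1` gives the lower of the two numbers measured so far in a functional assay on MDA-MB-231 cells (Homo sapiens) for antiproliferative activity, read by MTT assay, with a stated time of 72 h; a lower number here means a stronger inhibitor, a higher number a weaker inhibitor: compound 2 gives 600 nM, while compound 1 `NS(=O)(=O)Nc1ccc(NC(=O)Nc2cccc(-c3nc(-c4ccc(NC(=O)c5cccnc5)cc4Cl)no3)c2)cc1` gives 8900 nM. Going by the values given here, the one measured step, a 15-fold lower number from compound 1 to compound 2 (1.17 log units; beyond the scatter), is large, but it concerns the sulfonyl group and not the ring that carries it. Compound 3 `CS(=O)(=O)Nc1ccc(NC(=O)Nc2cccc(-c3nc(-c4ccc(NC(=O)c5cccnc5)cc4Cl)no3)c2)cc1Br` differs from compound 2 by bromo in place of hydrogen on an aromatic carbon. Among the compounds with values here, no measured step changes this position, so the data give no direct guide to the size or direction of the effect, and the single known step does not bear on it. The expected outcome is therefore a number near that of compound 2, with the step from compound 2 to compound 3 expected to be no change at the digits printed from compound 2 to compound 3 (within the scatter). Compound 3 is thus estimated in this assay at 600 nM, with a range from 200 nM to 2000 nM.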

Compound 3, half-maximal inhibitory concentration: 700 nM
Estimate against measurement, compound 3: 1.2-fold (0.07 log units) below, and the stated range covers the measured number.
By their numbers in this assay, from the lowest: compounds 2 and 3 (each within the scatter of the next); then compound 1.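

In this assay the ring carrying the methanesulfonamido group accepts a bromo group ortho to that group, and the step of a 1.2-fold higher number from compound 2 to compound 3 (0.07 log units; within the scatter) stays within the scatter. For the compounds shown here, the earlier compounds showed only that the group on the sulfonyl sulfur matters; this result shows that the number holds when this ring position carries bromo instead of hydrogen. The large step of a 13-fold lower number from compound 1 to compound 3 (1.10 log units; beyond the scatter) combines the bromo group with the exchange of 4-(sulfamoylamino)phenyl for the methanesulfonamido-bearing ring, so the potency of compound 3 still rests on the methanesulfonamido group, and nothing available explains why this position gives so little response.

From the compounds shown here alone, whether chloro, methoxy or an amine at this position would give a similar number stays open. So does whether bromo would behave the same with the sulfamoylamino group of compound 1.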